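Ureido in place of amino on the shared core

The source may hold more compounds than are shown below. What is called first, only, known or untested is meant among the compounds shown, and "the series" means these compounds.

Compound 1 `N#Cc1c(-c2ccccc2)cn(-c2ccc(S(=O)(=O)Nc3nccs3)cc2)c1N` gives 5360 nM in a functional assay on HepG2 cells (Homo sapiens) for inhibition, read by sulforhodamine B assay, with a stated time of 24 h; a higher number here means a weaker inhibitor, a lower number a stronger inhibitor. Compound 2 `N#Cc1c(-c2ccccc2)cn(-c2ccc(S(=O)(=O)Nc3ccccn3)cc2)c1N` gives 5300 nM, and compound 3 `O=c1[nH]cnc2c1c(-c1ccccc1)cn2-c1ccc(S(=O)(=O)Nc2ccccn2)cc1`, built on a different core, gives 4670 nM. The three numbers sit within the scatter of one another, compound 1 at the upper edge, so no ranking among them can be drawn.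

Compound 4 `N#Cc1c(-c2ccccc2)cn(-c2ccc(S(=O)(=O)Nc3nccs3)cc2)c1NC(N)=O` differs from compound 1 by carbamoyl in place of hydrogen on a nitrogen on an aromatic ring. Among the measured compounds shown here, the only measured step in the set is a 1.0-fold lower number from compound 1 to compound 2 (0.00 log units; within the scatter), which changes the group on the sulfonamide nitrogen and leaves the nitrogen on the aromatic ring untouched; it therefore does not speak to the present change. Compound 3 shares no single-point relation with compound 1 and adds nothing here either. For the measured compounds named here, no measured step touches the position altered in compound 4, so there is no basis for expecting a shift in either direction beyond the scatter.

The working expectation for compound 4 is accordingly a number close to that of compound 1: a 1.0-fold lower number from compound 1 to compound 4 (0.01 log units; within the scatter) is the estimated step. Compound 4 is estimated at 5200 nM, with a range from 2000 nM to 14000 nM.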

Compound 4, half-maximal inhibitory concentration: 4020 nM
Compound 4: the middle estimate sits 1.3-fold (0.11 log units) above what was measured; measured number inside the range.
By their numbers in this assay, from the lowest: compounds 4, 3, 2 and 1 (each within the scatter of the next).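

Amino to ureido, the first change read at this position, gives a 1.3-fold lower number from compound 1 to compound 4 (0.12 log units; within the scatter) in this assay. The nitrogen on an aromatic ring therefore takes carbamoyl in place of hydrogen, with its added carbonyl and terminal nitrogen, without a shift beyond the scatter, so this single change gives no sign that the position governs the reading in this assay. With this result, changes at two separate places on the thiazolyl compound, the group on the sulfonamide nitrogen and the group on the nitrogen on an aromatic ring, have each stayed within the scatter, and nothing on hand accounts for that outcome
.

The compounds shown leave open whether any group on this nitrogen moves the number beyond the scatter, for instance an acetyl group, a longer alkyl chain or a carboxylic acid on a chain. They also leave open whether the amino to ureido change reads the same when pyridin-2-yl replaces 1,3-thiazol-2-yl on the sulfonamide nitrogen, since only the 1,3-thiazol-2-yl pair carries this step.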